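Adding one methyl to the methoxy group of compound 3

A few compounds are considered here, and "the series" means these few. Any claim that something is new, unique, unknown or untested is made for them only; others in the source may bear on it.

Measured in a functional assay on HeLa cells (Homo sapiens) for antiproliferative activity, read by MTT assay, with a stated time of 72 h; a higher number here means a weaker inhibitor, a lower number a stronger inhibitor:
compound 1 `COc1cc(-c2nc(N(C)C)sc2-c2ccc3ccccc3c2)cc(OC)c1OC`: 1400 nM
compound 2 `COc1cc(-c2nc(N(C)C)sc2-c2ccc(C(F)(F)F)cc2)cc(OC)c1OC`: > 10000 nM (a limit of the assay)
compound 3 `COc1ccc(-c2sc(N(C)C)nc2-c2cc(OC)c(OC)c(OC)c2)cc1`: 3370 nM

Of the two results that are actual numbers, the higher belongs to compound 3, at 3370 nM. Compound 1 stands nearest to it, and the step between them is a 2.4-fold higher number from compound 1 to compound 3 (0.38 log units; beyond the scatter). The result for compound 2 is only a limit of the assay.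

Compound 4 `CCOc1ccc(-c2sc(N(C)C)nc2-c2cc(OC)c(OC)c(OC)c2)cc1` is the next to be tested. It differs from compound 3 by methyl in place of hydrogen on a saturated chain carbon bound to an oxygen on an aromatic ring, which turns methoxy into ethoxy and 4-methoxyphenyl into 4-ethoxyphenyl. For the measured compounds named here, no measured step makes this change, so the support is indirect. Two steps reach the 4-methoxyphenyl group of compound 3: a 2.4-fold higher number from compound 1 to compound 3 (0.38 log units; beyond the scatter) and an at least 2.9-fold lower number from compound 2 to compound 3 (0.47 log units; beyond the scatter). Each of these exchanges a larger piece of the structure than a single methyl, and each is only modest in size. In this assay, a smaller step is therefore expected, probably none beyond the scatter and with no clear direction. The expected step is a 1.1-fold lower number from compound 3 to compound 4 (0.05 log units; within the scatter). For compound 4 the estimated value is 3000 nM, with an expected range of 900 nM to 9000 nM.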

Compound 4, half-maximal inhibitory concentration: 3260 nM
Compound 4: the middle estimate sits 1.1-fold (0.04 log units) below what was measured; the measured number falls inside the stated range.
By their numbers in this assay, from the lowest: compound 1; then compounds 4 and 3 (each within the scatter of the next). At a limit, above all of these: compound 2.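

In this assay, for the compounds shown here, this is the first direct look at the saturated chain carbon bound to an oxygen on an aromatic ring, and adding one methyl there, which turns 4-methoxyphenyl into 4-ethoxyphenyl, leaves the result within the scatter: a 1.0-fold lower number from compound 3 to compound 4 (0.01 log units; within the scatter). The extra methyl also does not close the gap to the naphthalen-2-yl group, as the 4-ethoxyphenyl group stays on the weaker side of it, with a 2.3-fold higher number from compound 1 to compound 4 (0.37 log units; beyond the scatter), a step that is modest but beyond the scatter. Compound 2 gives only a limit of the assay, so exchanging its trifluoromethyl for ethoxy yields a bound and not an exact size, an at least 3.0-fold lower number from compound 2 to compound 4 (0.48 log units; beyond the scatter), and that bound rests on a single compound: the limit of > 10000 nM in this assay, at which 1 of the 4 values shown sits.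

A single methyl step cannot show whether the result stays flat as the chain grows, so a longer chain such as propoxy or butoxy at this place remains an open question. The compounds shown also leave open what a hydroxy group or an amine would do in place of the ethoxy group of compound 4.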